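The source may report more compounds than this note shows. Statements on the series, on what has been measured and on what is new or still open speak of the compounds shown alone.

Measured compounds:
- compound 1, `CCCCN(CC)c1nc(C)nc2c1n(C)c(=O)n2-c1c(C)cc(C)cc1C`: 4.4 nM
- compound 2, `CCCCC(CC)Nc1nc(C)nc2c1n(C)c(=O)n2-c1c(C)cc(C)cc1C`: 17.4 nM

Among the measured compounds shown here, in an assay on HEK293 cells for binding affinity to corticotropin-releasing factor receptor 1 (Homo sapiens), read by radioligand binding (on this read-out higher numbers stand for weaker inhibition and lower numbers for stronger inhibition), compound 1 gives the lowest of the two numbers in hand; its nearest neighbour is compound 2, and the step of a 4.0-fold higher number from compound 1 to compound 2 (0.60 log units; beyond the scatter) is the only measured step, a change at the amine on the shared core.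

The compound to be assessed is compound 3, `CCCCN(CC)c1nc(C)nc2c1n(C)c(=O)n2-c1c(C)cc(C)nc1C`. Relative to compound 1 the change is 2,4,6-trimethylpyridin-3-yl in place of 2,4,6-trimethylphenyl on an aromatic nitrogen. The measured step from compound 1 to compound 2 touches a different part of the core, the amine substituent, and says nothing about the aryl group on the ring nitrogen. For the measured compounds named here, no measured pair therefore bears on the change to compound 3, and the expectation rests on the unchanged remainder of compound 1 alone.

With nothing to point either way, compound 3 is expected to stay close to compound 1, a step of a 1.4-fold higher number from compound 1 to compound 3 (0.13 log units; within the scatter) that does not exceed the scatter. Compound 3 is accordingly estimated at 6 nM in this assay, with a range of 2 nM to 20 nM.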

Compound 3, inhibition constant: 124 nM
For compound 3 the middle estimate is 21-fold (1.32 log units) below the measured one; the measured number lies above the stated range.
By their numbers in this assay, from the lowest: compound 1; then compound 2; then compound 3.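

In this assay, the aryl group on the aromatic nitrogen proves highly sensitive to a change within its ring: 2,4,6-trimethylpyridin-3-yl in place of 2,4,6-trimethylphenyl gives a 28-fold higher number from compound 1 to compound 3 (1.45 log units; beyond the scatter), although both groups have 9 heavy atoms and the methyl pattern carried in the name stays the same. The only difference counted between the two groups is one ring carbon replaced by nitrogen, which brings in a hydrogen-bond acceptor, so this position tolerates far less than the earlier data could show; the step at the amine, a 4.0-fold higher number from compound 1 to compound 2 (0.60 log units; beyond the scatter), is modest, while this one is large. The compounds shown offer no measurement that accounts for the weaker inhibition.

Open, on these data alone, is whether other groups on the aromatic nitrogen, such as 2,4,6-trimethoxyphenyl or 2,4-dichlorophenyl, would stay close to compound 1 or fall away as the pyridinyl group does. Also open, as far as these compounds go, is whether 2,4,6-trimethylpyridin-3-yl would cost as much when paired with the (1-ethylpentyl)amino group of compound 2, or with a shorter chain on the amine such as dipropylamino.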